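Removing the allylsulfanyl group from compound 2

A few compounds are considered here, and "the series" means these few. Any claim that something is new, unique, unknown or untested is made for them only; others in the source may bear on it.

Measured so far:
Compound 1 `Cc1cc(Nc2cc(-c3ccccc3)[nH]n2)n2nc(SCc3cccc(Br)c3)nc2n1` gives 5140 nM in a functional assay on MCF7 cells (Homo sapiens) for inhibition, read by MTT assay, with a stated time of 72 h; a higher number here means a weaker inhibitor, a lower number a stronger inhibitor.
Compound 2 `C=CCSc1nc2nc(C)cc(Nc3cc(-c4ccccc4)[nH]n3)n2n1` is reported in this assay only as the limit > 50000 nM.

Compound 2 therefore stands at a bound of this assay, not at a number. For the measured compounds named here, the single measured step, an at least 9.7-fold higher number from compound 1 to compound 2 (0.98 log units; beyond the scatter), shows that exchanging the group on the sulfur already carried the value to that bound (the limit of > 50000 nM in this assay, at which 1 of the 2 values shown sits). Compound 3 `Cc1cc(Nc2cc(-c3ccccc3)[nH]n2)n2ncnc2n1` goes one step further: hydrogen in place of allylsulfanyl on an aromatic carbon. Going by the values given here, no measured step removes the whole allylsulfanyl, so the expectation rests only on the direction seen from compound 1 to compound 2, where a smaller group on the sulfur went with weaker inhibition. Compound 3 is expected to remain weak, with an estimated step that the limit leaves unreadable from compound 2 to compound 3 that a limit cannot resolve. For compound 3 the estimate is 60000 nM, between 15000 nM and 200000 nM, most probably reported again as a limit.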

Compound 3, half-maximal inhibitory concentration: > 50000 nM
Compound 3 was reported as a limit (the forecaster's own chance of this, stated with the estimate: 65%); the middle value lies beyond the limit too.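

In this assay, hydrogen on this aromatic carbon gives no measured value either, so among the three groups shown at this place, only the (3-bromobenzyl)sulfanyl of compound 1 yields a number. Replacing that group with hydrogen gives an at least 9.7-fold higher number from compound 1 to compound 3 (0.98 log units; beyond the scatter). Compound 3 is reported only as a limit, the same one as compound 2, so the step between them cannot be read and the allylsulfanyl cannot be told apart from hydrogen here: the limit of > 50000 nM in this assay, at which 2 of the 3 values shown sit.

What remains open is which part of the (3-bromobenzyl)sulfanyl group goes with the measured value, since a benzylsulfanyl without the bromine is not among the compounds shown. Also open, as far as these compounds go, is whether a group not bound through sulfur, such as an amine on this carbon, would give a number at all.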